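The compounds below may be only part of what the source reports. "The series", "measured", "known", "first", "only" and "open" are said of these compounds alone.

In an ADME assay on CHO cells (Cricetulus griseus) for cytotoxicity, read by MTT assay, with a stated time of 48 h (a higher number here means a weaker inhibitor, a lower number a stronger inhibitor), compound 1 `Clc1ccc2c(NCCCn3c(-c4ccccc4)nc4ccccc43)ccnc2c1` gives 42000 nM and compound 3 `CS(=O)(=O)c1ccc2c(c1)nc(-c1ccccc1)n2CCCNc1ccnc2cc(Cl)ccc12` gives 40900 nM, so the two stand level. With methylsulfonyl in place of hydrogen on an aromatic carbon, the values show a 1.0-fold lower number from compound 1 to compound 3 (0.01 log units; within the scatter). Compound 2 `Cc1ccc2c(c1)nc(-c1ccccc1)n2CCCNc1ccnc2cc(Cl)ccc12` reaches only a limit of the assay, > 50000 nM. This is the limit of > 50000 nM in this assay, at which 1 of the 3 values shown sits. The two steps through that compound are therefore floors: an at least 1.1-fold higher number from compound 1 to compound 2 (0.07 log units; that floor lies within the scatter), and an at least 1.2-fold lower number from compound 2 to compound 3 (0.08 log units; that floor lies within the scatter). Neither floor lies beyond the scatter.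

Compound 4 `N#Cc1ccc2c(c1)nc(-c1ccccc1)n2CCCNc1ccnc2cc(Cl)ccc12` carries cyano in place of methylsulfonyl on an aromatic carbon. Going by the values given here, no measured step bears on this exchange directly, but the three above all concern substitution at the same place. Because the only fully numerical one is a 1.0-fold lower number from compound 1 to compound 3 (0.01 log units; within the scatter), no step beyond the scatter is expected in this assay, though another limit remains possible. The estimated step is a 1.0-fold higher number from compound 3 to compound 4 (0.01 log units; within the scatter). For compound 4 the expected value is 42000 nM, with an estimated range from 22000 nM to 75000 nM.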

Compound 4, half-maximal inhibitory concentration: 38900 nM
The estimate for compound 4 lay 1.1-fold (0.03 log units) above the measured number, within the range that was stated.
By their numbers in this assay, from the lowest: compounds 4, 3 and 1 (each within the scatter of the next). At a limit, above all of these: compound 2.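

In this assay, cyano now stands with hydrogen and methylsulfonyl on this aromatic carbon with no step beyond the scatter: the exchange for methylsulfonyl gives a 1.1-fold lower number from compound 3 to compound 4 (0.02 log units; within the scatter), and the exchange for hydrogen gives a 1.1-fold lower number from compound 1 to compound 4 (0.03 log units; within the scatter). Going by these compounds alone, this is the first direct exchange between two substituents at this position that can be read as a full number, and it shows that replacing methylsulfonyl with cyano leaves the values level. The exchange for methyl can be read only as a floor, an at least 1.2-fold lower number from compound 2 to compound 4 (0.10 log units; that floor lies within the scatter), and it rests on a limit: the limit of > 50000 nM in this assay, at which 1 of the 4 values shown sits.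

As far as these compounds go, whether compound 2 truly differs from the other compounds remains open. Also open, from the compounds shown here alone, is whether an amine or a carboxylic acid on this aromatic carbon would give a step beyond the scatter.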